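From propanoylamino to vinylcarbonyl on a shared core

The source may hold more compounds than are shown below. What is called first, only, known or untested is meant among the compounds shown, and "the series" means these compounds.

In an ADME assay on BaF3 cells (Mus musculus) for cytotoxicity, read by CellTiter-Glo and CCK-8 assay, with a stated time of 72 h (a lower number here means a stronger inhibitor of growth, a higher number a weaker inhibitor of growth), two compounds built on the shared core have been read so far. Compound 1 `C=CC(=O)NCc1ccc(C(=O)Nc2ccc(C)c(Nc3nccc(-c4cccnc4)n3)c2)cc1` gives > 10000 nM, which is a limit of the assay and not a number. Compound 2 `CCC(=O)Nc1ccc(C(=O)Nc2ccc(C)c(Nc3nccc(-c4cccnc4)n3)c2)cc1` gives > 10000 nM, which is likewise a limit. Compound 2 therefore has no number of its own, and the readings so far amount to the limit of > 10000 nM in this assay, at which 2 of the 2 values shown sit.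

Compound 3 `C=CC(=O)Nc1ccc(C(=O)Nc2ccc(C)c(Nc3nccc(-c4cccnc4)n3)c2)cc1` differs from compound 2 by a single change, vinyl in place of ethyl on a carbonyl carbon. Among the compounds with values here, the only measured step nearby is a step that the two limits leave unreadable from compound 1 to compound 2, and it offers no size to carry over. Compound 1 also holds a vinylcarbonyl group and still reads > 10000 nM, so the presence of that group has not yet produced a number. Only a small move towards stronger growth inhibition is expected in this assay, and the reading may well remain a limit. The estimated change is an at least 1.2-fold lower number from compound 2 to compound 3 (0.09 log units; that floor lies within the scatter). Compound 3 is expected to read about 8000 nM, with an estimated range of 2500 nM to 20000 nM.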

Compound 3, concentration for 50% growth inhibition: 5600 nM
The estimate for compound 3 lay 1.4-fold (0.15 log units) above the measured number, and the stated range covers the measured number.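

Within the data shown here, compound 3 is the first compound on the shared core to give a number rather than a limit in this assay, and it shows that the vinyl group on this carbonyl carbon, whose other neighbour is an amide-type nitrogen, can go with measurable growth inhibition where ethyl gave none that could be read. Vinyl in place of ethyl gives an at least 1.7-fold lower number from compound 2 to compound 3 (0.25 log units; that floor lies within the scatter), while (vinylcarbonyl)amino in place of ((vinylcarbonyl)amino)methyl on an aromatic carbon gives an at least 1.7-fold lower number from compound 1 to compound 3 (0.25 log units; that floor lies within the scatter), so neither floor alone establishes a real difference. Compound 1 also holds the vinylcarbonyl group, and its > 10000 nM is a limit of the assay and not a number, so that group alone did not yield a reading.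

The step between the two compounds that read as limits cannot be read, and most of this small set still gives no number: the limit of > 10000 nM in this assay, at which 2 of the 3 values shown sit. The compounds shown leave open how large either step truly is, and what a longer chain or an amine in place of vinyl on the same carbonyl carbon would read in this assay.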